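The compounds below may be only part of what the source reports. "The series", "measured", "known", "first", "only" and "open" are said of these compounds alone.

Compound 2, `C[C@H](NC(=O)c1cc(C(F)(F)F)nn1C)c1nc(-c2ccnc(N3CCCC3)c2)no1`, gives 41000 nM in a physicochemical assay for solubility, measured as kinetic solubility; a lower number here means a less soluble compound, a higher number a more soluble compound. Among the three compounds measured it holds the second highest number. Compound 1, `COc1cc(-c2noc([C@H](C)NC(=O)c3cc(C(F)(F)F)nn3C)n2)ccn1`, gives 156000 nM, and the step of a 3.8-fold lower number from compound 1 to compound 2 (0.58 log units; beyond the scatter) separates the two. Compound 3, `COc1cc(-c2noc([C@H](C)NC(=O)c3cc(C(F)(F)F)nn3C)n2)cc(C)n1`, gives 3000 nM, the lowest of the three, reached from compound 1 by a 52-fold lower number from compound 1 to compound 3 (1.72 log units; beyond the scatter); set against compound 2, compound 3 shows a much lower number.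

Compound 4, `C[C@H](NC(=O)c1cc(C(F)(F)F)nn1C)c1nc(-c2ccnc(C(F)F)c2)no1`, is the unmeasured compound. It differs from compound 2 by difluoromethyl in place of pyrrolidin-1-yl on an aromatic carbon.

For the measured compounds named here, of the two measured steps, only the one from compound 1 to compound 2 touches the same position on the ring, and it was modest. The step from compound 1 to compound 3 concerns a different position and a different kind of change, so it bears only loosely here. Going by the values given here, no measured pair exchanges pyrrolidin-1-yl for difluoromethyl, so the direction is uncertain. A small step in this assay is therefore expected, in either direction, and likely not far beyond the scatter.

Compound 4 is estimated to give 60000 nM, within a range of 20000 nM to 180000 nM, which means an expected step of a 1.5-fold higher number from compound 2 to compound 4 (0.17 log units; within the scatter).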

Compound 4, solubility: 178000 nM
The estimate for compound 4 lay 3.0-fold (0.47 log units) below the measured number; the measured number falls inside the stated range.
By their numbers in this assay, from the lowest: compound 3; then compound 2; then compounds 1 and 4 (each within the scatter of the next).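

At this position, on an aromatic carbon next to the ring nitrogen, the exchange of pyrrolidin-1-yl for difluoromethyl gives a 4.3-fold higher number from compound 2 to compound 4 (0.64 log units; beyond the scatter) in this assay, while a 1.1-fold higher number from compound 1 to compound 4 (0.06 log units; within the scatter) shows that difluoromethyl and methoxy cannot be told apart here, so that of the three groups seen at this place only pyrrolidin-1-yl stands apart, with the lower number. For the compounds shown here, the earlier compounds showed only one exchange at this place, and compound 4 adds a second group whose number matches that of compound 1 rather than that of compound 2, although the step of a 59-fold higher number from compound 3 to compound 4 (1.77 log units; beyond the scatter) spans a whole group of the molecule, with the methyl of compound 3 and the methoxy both leaving, and so cannot be given to either alone. Nothing measured here explains why the groups at this place differ as they do.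

The compounds shown leave open whether the lower number of compound 2 goes with amines at this place in general or with pyrrolidin-1-yl alone, which an open-chain dimethylamino group or a morpholine ring would test. They also leave open how trifluoromethyl or a plain hydrogen would stand beside difluoromethyl and methoxy at this place.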